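Methyl to cyclopentyl on the shared core

The source may hold more compounds than are shown below. What is called first, only, known or untested is meant among the compounds shown, and "the series" means these compounds.

Among the measured compounds shown here, in a functional assay on the whole organism with Canis familiaris (Canis lupus familiaris) as the target (a higher number here means that more compound is needed for the effect, a lower number that less compound is needed), compound 1 (`COc1cc2c(C)nc(O)c(C)c2cc1OC`) holds the lower of the two numbers so far, at 0.04 mg/kg, while compound 2 (`COc1cc2c(C)nc(O)c(Cl)c2cc1OC`) gives 0.12 mg/kg. Compound 3 (`COc1cc2c(C)nc(O)c(C3CCCC3)c2cc1OC`) has cyclopentyl in place of methyl on an aromatic carbon. For the measured compounds named here, the one measured change at that place is chloro in place of methyl, a 3.0-fold higher number from compound 1 to compound 2 (0.48 log units; beyond the scatter). Going by the values given here, no measured compound carries a ring there, so the guide is thin. A step of similar size towards a higher number is expected, and the estimated step is a 5.0-fold higher number from compound 1 to compound 3 (0.70 log units; beyond the scatter). Compound 3 is expected at 0.2 mg/kg, within an estimated range of 0.05 mg/kg to 0.8 mg/kg.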

Compound 3, dose for half-maximal effect: 1.88 mg/kg
Compound 3: the middle estimate sits 9.4-fold (0.97 log units) below what was measured; the whole stated range lies below it.
By their numbers in this assay, from the lowest: compound 1; then compound 2; then compound 3.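

At this place on the shared core, the step to cyclopentyl in this assay is large, a 47-fold higher number from compound 1 to compound 3 (1.67 log units; beyond the scatter), far beyond the modest step seen with chloro. Cyclopentyl also falls well behind chloro, a 16-fold higher number from compound 2 to compound 3 (1.19 log units; beyond the scatter), so neither replacement shown gives a lower number than methyl. Nothing available explains the size of this step. The compounds shown leave open whether a smaller ring such as cyclopropyl, an open chain such as ethyl, or an amine at this place would keep the number close to that of compound 1.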